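Aryloxyacetic acid series: substituted phenyl in place of phenyl

The source may report more compounds than this note shows. Statements on the series, on what has been measured and on what is new or still open speak of the compounds shown alone.

Measured compounds:
compound 1 `CCCOc1cc(C)c(-c2cccc(CNc3ccc(OCC(=O)O)c(F)c3)c2)c(C)c1` — 38.7 nM
compound 2 `O=C(O)COc1ccc(NCc2cccc(-c3ccccc3)c2)cc1F` — 58.5 nM
compound 3 `O=C(O)COc1ccc(NCc2ccc(Cl)c(-c3ccccc3)c2)cc1F` — 51.7 nM

In a functional assay on CHO cells for agonist activity at Free fatty acid receptor 1 (Homo sapiens), read by FLIPR and calcium flux (a higher number here means that more compound is needed for the effect, a lower number that less compound is needed), compound 2 has the highest of the three numbers. Its nearest neighbour is compound 3, which gives 51.7 nM; the furthest is compound 1, which gives 38.7 nM. Both gaps are within the scatter, so no order among the three can be read from them.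

Compound 4 `CCOc1ccc(-c2cccc(CNc3ccc(OCC(=O)O)c(F)c3)c2)c(C)c1` is not yet measured. It differs from compound 2 in one place: 4-ethoxy-2-methylphenyl in place of phenyl on an aromatic carbon.

Going by the values given here, only one single-site step is known, a 1.1-fold lower number from compound 2 to compound 3 (0.05 log units; within the scatter), and it concerns a different site, so it says little about the change to compound 4. A substituted phenyl stands at the same place in compound 1 as in compound 4. Compound 1 gives 38.7 nM. Compound 2 gives 58.5 nM, a gap within the scatter. A step of no more than the scatter is therefore expected in this assay, from compound 2 to compound 4: a 1.4-fold lower number from compound 2 to compound 4 (0.14 log units; within the scatter). Compound 4 is estimated at 42 nM, with a range from 15 nM to 120 nM.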

Compound 4, half-maximal effective concentration: 11.6 nM
For compound 4 the middle estimate is 3.6-fold (0.56 log units) above the measured one, outside the stated range (below it).
By their numbers in this assay, from the lowest: compound 4; then compounds 1, 3 and 2 (each within the scatter of the next).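

In this assay, going by these compounds alone, the phenyl on the aromatic carbon, meta to a large group, proves open to substitution: 4-ethoxy-2-methylphenyl gives a 5.0-fold lower number from compound 2 to compound 4 (0.70 log units; beyond the scatter) and this is the first single-site step to lie beyond the scatter. Within the data shown here, the chloro step on the other site, a 1.1-fold lower number from compound 2 to compound 3 (0.05 log units; within the scatter) stayed within it, so this position is the one of the two that has moved the number so far. The entering group brings 10 heavy atoms against 6 and 1 hydrogen-bond acceptor against 0, but no measurement shown here bears on why the number falls.

The compounds shown leave open whether the step belongs to the ethoxy, to the methyl or only to the two together. Also open, going by these compounds, is how an amine or a hydroxyl on a longer chain would fare in place of the ethoxy.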